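This account rests on a few compounds, and the source may have more. Where it says the series, first, only, none or still open, it means among the compounds named here.

In a functional assay on the whole organism (blood) with Rattus norvegicus as the target, with stated times of 24 h and 1 h, at a dose of 5 mg/kg by the intraperitoneal route (on this read-out lower numbers stand for a weaker effect and higher numbers for a stronger effect at the one dose given), three compounds have been measured, and their numbers sit close together. Compound 1, `Cc1ncsc1C(=O)NCCC1CCN(S(=O)(=O)NC(=O)NC[C@@H]2C[C@@H]3C=C[C@@H]2C3)CC1`, gives 11% in this assay. Compound 2, `CCCNC(=O)NS(=O)(=O)N1CCC(CCNC(=O)c2cscn2)CC1`, gives 10% in this assay, and compound 3, `O=C(NC1CCCCC1)NS(=O)(=O)N1CCC(CCNC(=O)c2ccnc3ccccc23)CC1`, gives 16% in this assay. The number for compound 1 lies within the usual scatter of both compound 2 and compound 3, so no ordering among the three can be read from these readings.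

Compound 4, `COc1ccc2nccc(C(=O)NCCC3CCN(S(=O)(=O)NC(=O)NC[C@@H]4C[C@@H]5C=C[C@@H]4C5)CC3)c2c1`, has not yet been measured in this assay. It differs from compound 1 in one place: 6-methoxyquinolin-4-yl in place of 4-methyl-1,3-thiazol-5-yl on a carbonyl carbon. The rest of the shared core, with its sulfamide-urea end, stays the same.

Among the measured compounds shown here, no step between two measured compounds isolates this change, so the only guide is the small spread of the three numbers. A change that stays within the scatter is expected, with at most a slight lean upward because compound 3, which also carries an amide built on a quinoline-type ring, gives 16%. The step from compound 1 to compound 4 is therefore expected to be a number 4 percentage points higher from compound 1 to compound 4 (within the scatter). For compound 4 in this assay the expected reading is 15%, within a range from 5% to 28%.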

Compound 4, a percentage reported as activity, at one dose (the size of the read-out at that dose, not a potency): 10%
Estimate against measurement, compound 4: 5 percentage points above; measured number inside the range.
By their numbers in this assay, from the lowest: compounds 2, 4, 1 and 3 (each within the scatter of the next).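

Placing 6-methoxyquinolin-4-yl in place of 4-methyl-1,3-thiazol-5-yl on a carbonyl carbon gives a number 1 percentage points lower from compound 1 to compound 4 (within the scatter) in this assay and is the first comparison here in which only one place differs. On this read-out, the position therefore holds a group of 12 heavy atoms with two six-membered aromatic rings in place of one of 6 heavy atoms with a single five-membered aromatic ring, and the two compounds cannot be told apart. Nothing at hand gives a measured reason for this reading or shows what the two groups do in the animal.

The compounds shown leave open whether a plain phenyl ring, a simple alkyl chain or a group carrying a carboxylic acid or an amine on this carbonyl carbon would read any differently from compound 1 on the same shared core. They also leave open what the methoxy group adds, which a quinolin-4-yl group without it on the core of compound 1 would test directly, and whether the two compounds would stay this close at a dose other than the single one used here.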